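The compounds below may be only part of what the source reports. "The series", "measured", "known", "first", "only" and "open" are said of these compounds alone.

Measured in an ADME assay on PA-1 cells (Homo sapiens) for cytotoxicity, read by MTT assay, with a stated time of 72 h; a higher number here means a weaker inhibitor, a lower number a stronger inhibitor:
- compound 1 `COc1ccc(C2=C(c3cc(OC)c(OC)c(OC)c3)C(=O)C(O)C2)cc1NC(=O)c1ccccc1`: > 100 ug/mL (a limit)
- compound 2 `COC(=O)c1cc(C2=C(c3cc(OC)c(OC)c(OC)c3)C(=O)CC2O[SiH2]C(C)(C)C)ccc1OC`: > 100 ug/mL (a limit)
- compound 3 `COc1ccc(C2=C(c3cc(OC)c(OC)c(OC)c3)C(=O)CC2O)cc1O`: < 1 ug/mL (a limit)

Compound 1 gives no number, only a limit, and it sits at the limit of > 100 ug/mL in this assay, at which 2 of the 3 values shown sit. Compound 3 sits at the other end, at the limit of < 1 ug/mL in this assay, at which 1 of the 3 values shown sits.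

Compound 4 `COc1ccc(C2=C(c3cc(OC)c(OC)c(OC)c3)C(=O)C(O)C2)cc1F` keeps the core of compound 1 and carries fluoro in place of benzamido on an aromatic carbon, ortho to a methoxy group: fluoro in place of benzamido on an aromatic carbon.

Among the compounds with values here, no measured pair differs in one place only, so the reading of this change rests on indirect comparison. Compound 3 carries no benzamido and gives a limit, < 1 ug/mL. Compound 2 also carries no benzamido and gives a limit too, > 100 ug/mL. The absence of benzamido alone therefore does not settle the outcome, and compound 2 goes against any simple trend.

In this assay a large move toward stronger inhibition is still expected, beyond the scatter, and the estimated at least 25-fold lower number from compound 1 to compound 4 (1.39 log units; beyond the scatter) carries wide uncertainty. The expected value for compound 4 is 4 ug/mL, with an estimated range from 0.4 ug/mL to 100 ug/mL.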

Compound 4, half-maximal inhibitory concentration: > 100 ug/mL
Compound 4: a limit, no number; the forecaster's own chance of this, stated with the estimate: 35%; middle value at least 25-fold (1.39 log units) from the limit.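

In this assay compound 4 gives > 100 ug/mL, which is a limit and not a number. Within the data shown here, compound 1 also stands at a limit, so no step between compound 1 and compound 4 can be read. The compounds shown leave open what size of change, if any, fluoro in place of benzamido on an aromatic carbon brings in this assay.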